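The source may report more compounds than this note shows. Statements on the series, on what has been measured and on what is new or still open speak of the compounds shown alone.

Measured so far:
compound 1 `COc1ccc(-c2cc(=O)c3c(OC)cc(OC)cc3[nH]2)cc1` — in a functional assay on HepG2 cells (Homo sapiens) for antiproliferative activity, with a stated time of 72 h (on this read-out lower numbers stand for an effect already at smaller amounts and higher numbers for an effect only at larger amounts of compound), compound 1 gives > 31100 nM, which is a limit of the assay and not a number.
compound 2 `COc1ccc(-c2cc(=O)c3c(OC)cc(OC)cc3n2S(=O)(=O)c2cc(Cl)cc(Cl)c2O)cc1` — in this assay compound 2 gives > 37900 nM, likewise a limit of the assay and not a number.

Compound 2 therefore stands at the limit of > 37900 nM in this assay, at which 1 of the 2 values shown sits, and compound 1 at the limit of > 31100 nM in this assay, at which 1 of the 2 values shown sits; both values shown are limits, so the two compounds show no measurable effect in this assay and nothing can be said about any difference between them. The aryl sulfonyl group on the ring nitrogen of compound 2 gives no change that can be read off against compound 1, since neither value is a number.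

Compound 3 `COc1ccc(-c2cc(=O)c3c(OC)cc(OC)cc3n2S(=O)(=O)c2ccc(OC)cc2)cc1` differs from compound 2 by 4-methoxyphenyl in place of 3,5-dichloro-2-hydroxyphenyl on a sulfonyl sulfur. Among the compounds with values here, no step between measured compounds exists, and both anchors sit at limits. The expectation for compound 3 is therefore that this assay again returns only a limit, with a step that the limit leaves unreadable from compound 2 to compound 3 being no step beyond the scatter. The estimate for compound 3 in this assay is 40000 nM, with a range from 8000 nM to 120000 nM.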

Compound 3, half-maximal effective concentration: > 82700 nM
Compound 3 ended at the assay's limit (the forecaster's own chance of this, stated with the estimate: 75%); middle value at least 2.0-fold (0.31 log units) from the limit.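

In this assay compound 3 gives > 82700 nM, which is a limit of the assay and not a number. Within the data shown here, compound 1, compound 2 and compound 3 all sit at limits, and no step between them can be read. The compounds shown leave open whether any group on the sulfonyl sulfur or on the aromatic nitrogen gives a measurable effect in this assay.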